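Swapping the Aryl Ring for Pyrrole in a Growth Inhibitor

The compounds below may be only part of what the source reports. "The series", "measured", "known", "first", "only" and "open" are said of these compounds alone.

Compound 1 `COc1ccc(/C=C(/Sc2ccc(C)cc2)C(=O)c2ccc(Cl)cc2)cc1O` has the lower of the two numbers recorded in a functional assay on DU-145 cells (Homo sapiens) for inhibition, read by trypan blue exclusion, with a stated time of 96 h (a higher number here means a weaker inhibitor of growth, a lower number a stronger inhibitor of growth), where compound 1 gives 1000 nM. For the measured compounds named here, compound 2 `O=C(/C(=C\c1ccc([N+](=O)[O-])c(O)c1)SCc1ccc(Br)cc1)c1cc(Cl)ccc1O` is the only neighbour, and in this assay compound 2 gives 10000 nM, a weaker result that lies beyond the scatter. Compound 3 `Cc1ccc(S/C(=C/c2ccc[nH]2)C(=O)c2ccc(Cl)cc2)cc1` differs from compound 1 by 1H-pyrrol-2-yl in place of 3-hydroxy-4-methoxyphenyl on a double-bonded chain carbon bound to a double-bonded chain carbon. Going by the values given here, no measured pair shows this change, so its effect is unknown; a modest loss of growth inhibition is expected, roughly a 2.5-fold higher number from compound 1 to compound 3 (0.40 log units; beyond the scatter). Compound 3 is therefore estimated at 2500 nM, within 600 nM to 12000 nM.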

Compound 3, concentration for 50% growth inhibition: 10000 nM
For compound 3 the middle estimate is 4.0-fold (0.60 log units) below the measured one, and the stated range covers the measured number.
By their numbers in this assay, from the lowest: compound 1; then compounds 2 and 3 (each within the scatter of the next).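

For the compounds shown here, replacing 3-hydroxy-4-methoxyphenyl with 1H-pyrrol-2-yl on this double-bonded chain carbon gives a 10-fold higher number from compound 1 to compound 3 (1.00 log units; beyond the scatter) in this assay, the first direct reading of a change at this position. The position is therefore sensitive to which aromatic ring it carries, and the smaller ring does not keep the growth inhibition of compound 1. Nothing available explains this loss. Still open, from the compounds shown here alone, is whether the ring size or the hydroxy and methoxy groups matter more. A plain phenyl or a 3-hydroxyphenyl ring at this place could help separate the two.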